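From Butyl to Cyclohexyl on an Aromatic Nitrogen

The source may hold more compounds than are shown below. What is called first, only, known or untested is meant among the compounds shown, and "the series" means these compounds.

- compound 1 `CCCCc1ccc(-c2c(C)[nH]c(=O)n2C)cc1`: 10700 nM
- compound 2 `CCCCc1ccc(-c2c(C)[nH]c(=O)n2CCCC)cc1`: 12000 nM

In a functional assay on brain (Rattus norvegicus, strain Wistar) for inhibition (on this read-out lower numbers stand for stronger inhibition and higher numbers for weaker inhibition), compound 2 gives 12000 nM, which stands within the scatter of compound 1. The next structure, compound 3 `CCCCc1ccc(-c2c(C)[nH]c(=O)n2C2CCCCC2)cc1`, carries cyclohexyl in place of butyl on an aromatic nitrogen.

Among the measured compounds shown here, only one measured step bears on this change. It concerns the same nitrogen substituent and is a 1.1-fold higher number from compound 1 to compound 2 (0.05 log units; within the scatter). For the measured compounds named here, that chain extension left the number within the scatter, but no compound yet carries a ring at this place, so the evidence is thin. No step beyond the scatter is therefore expected in this assay, and the estimate is a 1.1-fold lower number from compound 2 to compound 3 (0.04 log units; within the scatter). For compound 3 the expected value is 11000 nM, with an estimated range from 4500 nM to 27000 nM.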

Compound 3, half-maximal inhibitory concentration: 27100 nM
Compound 3: middle estimate off by 2.5-fold (0.39 log units), on the low side; the whole stated range lies below it.
By their numbers in this assay, from the lowest: compounds 1 and 2 (each within the scatter of the next); then compound 3.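

In this assay, among the compounds shown here, cyclohexyl is the first substituent on this aromatic nitrogen to move the number beyond the scatter, with a 2.3-fold higher number from compound 2 to compound 3 (0.35 log units; beyond the scatter) and a 2.5-fold higher number from compound 1 to compound 3 (0.40 log units; beyond the scatter), both toward weaker inhibition. Methyl and butyl had stayed within the scatter of each other, so this nitrogen does not treat all carbon substituents alike: one six-membered non-aromatic ring of carbon only in place of butyl weakens inhibition modestly, where the longer open chain had not changed it. Nothing given here accounts for this step.

These three compounds cannot separate the effect of the ring from that of the higher carbon count, a question that a hexyl chain would address. Going by these compounds, how an amine or a carboxylic acid carried on a chain at this nitrogen would read in this assay also remains open.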